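Phenyl for propanoyl: expected half-life of compound 4

The source may hold more compounds than are shown below. What is called first, only, known or untested is meant among the compounds shown, and "the series" means these compounds.

Compound 1 (`CCC(=O)N1CCC(C(=O)N2N=CCC2c2ccccc2)CC1`) gives 1.07 h as its half-life in an ADME assay on microsomes (Rattus norvegicus) for metabolic stability (a lower number here means that the compound disappears faster, a higher number that the compound lasts longer), on the shared core. Compound 2 (`O=C(C1CCC1)N1N=CCC1c1ccccc1`) gives 0.583 h as its half-life in this assay, and the numbers of compound 1 and compound 2 lie within the scatter of each other. Compound 3 (`CC(C)(C)C(=O)N1N=CCC1C1CCCCC1`) gives < 0.0234 h in this assay, and this is a limit of the assay rather than a number. Among the measured compounds shown here, compound 1 therefore stands level with compound 2, the only other compound with a number.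

Compound 4 (`O=C(C1CCN(c2ccccc2)CC1)N1N=CCC1c1ccccc1`) keeps the core of compound 1 and carries phenyl in place of propanoyl on an amine nitrogen in a ring. For the measured compounds named here, no measured pair isolates this change, so the expectation rests on thin ground. A moderate fall in this assay is expected, although a result within the scatter of compound 1 remains possible. This expectation leans on compound 3, whose < 0.0234 h is a limit. The expected change is a 3.1-fold lower number from compound 1 to compound 4 (0.49 log units; beyond the scatter) in this assay for now. Compound 4 is estimated at 0.35 h, with an expected range from 0.1 h to 1 h.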

Compound 4, half-life: 0.25 h
Compound 4: middle estimate off by 1.4-fold (0.15 log units), on the high side; low and high end bracket the measured number.
By their numbers in this assay, from the lowest: compound 4; then compounds 2 and 1 (each within the scatter of the next). At a limit, below all of these: compound 3.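

Among the compounds shown here, the step at this place, on an amine nitrogen in a ring of a six-membered non-aromatic ring, gives the first reading of a single change: with phenyl in place of propanoyl, this assay shows a 4.3-fold lower number from compound 1 to compound 4 (0.63 log units; beyond the scatter). For the compounds shown here, the half-life therefore responds to the group on this nitrogen, at least for this pair on the core of compound 1, something the earlier compounds could not show, as no two of them differ in only one place. Compound 3 gives < 0.0234 h, which is a limit of the assay and not a number, and it adds nothing to the reading of this step: the limit of < 0.0234 h in this assay, at which 1 of the 4 values shown sits.

One step cannot separate the loss of the hydrogen-bond acceptor and the double bond of propanoyl from the arrival of the aromatic ring of phenyl, and the size of the group changes with them, so which of these differences goes with the lower number stays unresolved. Also open, from the compounds shown here alone, is where other groups on this nitrogen would fall relative to compound 1 and compound 4, for instance a pyridine ring, which would keep an aromatic ring while adding a ring nitrogen, or a simple acetyl group, which would keep the carbonyl on a shorter chain.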